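This account rests on a few compounds, and the source may have more. Where it says the series, first, only, none or still open, it means among the compounds named here.

Measured so far in a functional assay on MCF7 cells (Homo sapiens) for inhibition, read by MTT assay, with a stated time of 72 h; on this read-out higher numbers stand for weaker inhibition and lower numbers for stronger inhibition:
compound 1, `O=C(Nc1ccccc1Cl)c1ccc(/N=N\c2c[nH]c3ccccc23)cc1`, gives 112000 nM;
compound 2, `Cc1ccccc1NC(=O)c1ccc(/N=N\c2c[nH]c3ccccc23)cc1`, gives 73400 nM.

For the measured compounds named here, compound 2 holds the lower of the two numbers, but its only neighbour is compound 1, and the step of a 1.5-fold lower number from compound 1 to compound 2 (0.18 log units; within the scatter) lies within the scatter, so the two measured compounds cannot be told apart on this read-out.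

Compound 3, `O=C(Nc1cccc([N+](=O)[O-])c1)c1ccc(/N=N\c2c[nH]c3ccccc23)cc1`, differs from compound 2 in one place: 3-nitrophenyl in place of 2-methylphenyl on an amide-type nitrogen. Going by the values given here, the one measured step, a 1.5-fold lower number from compound 1 to compound 2 (0.18 log units; within the scatter), concerns a different exchange on the same ring and was within the scatter; it says only that this part of the molecule has so far tolerated a small change without a shift beyond noise. Among the compounds with values here, no measured compound carries a nitro group, and no measured compound carries a substituent at the position named for compound 3, so the data give no direct guide to the new group. Without such evidence the step from compound 2 to compound 3 is expected to stay within the scatter, a 1.1-fold higher number from compound 2 to compound 3 (0.04 log units; within the scatter). For compound 3 the number in this assay is estimated at 80000 nM, with a range from 30000 nM to 220000 nM.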

Compound 3, half-maximal inhibitory concentration: 51900 nM
The estimate for compound 3 lay 1.5-fold (0.19 log units) above the measured number; the range from low to high includes it.
By their numbers in this assay, from the lowest: compounds 3, 2 and 1 (each within the scatter of the next, the first and the last beyond it).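

In this assay, the amide-type nitrogen takes 3-nitrophenyl in place of 2-methylphenyl with no shift that can be read (a 1.4-fold lower number from compound 2 to compound 3 (0.15 log units; within the scatter)), so this larger group, which brings a nitro function to the series, is accommodated at this position. For the compounds shown here, measured against 2-chlorophenyl, the same group gives the only step among the three compounds that passes the scatter (a 2.2-fold lower number from compound 1 to compound 3 (0.33 log units; beyond the scatter)), but it is modest, and compound 2 lies within the scatter of both compound 1 and compound 3, so the three aryl groups form no clear ranking. Nothing measured here accounts for the difference between compound 1 and compound 3.

The exchange from 2-chlorophenyl to 3-nitrophenyl alters both the substituent and its place on the ring, and the compounds shown do not separate these two changes. Also open, on these data alone, is whether an amine or a carboxylic acid on this ring, or a longer chain in place of the ring, would move the number in this assay by more than this modest step.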